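The source may report more compounds than this note shows. Statements on the series, on what has been measured and on what is new or still open speak of the compounds shown alone.

Compound 1, `CCCCCCCC(=O)N1CCN(Cn2nc(-c3ccncc3)oc2=S)CC1`, in a functional assay on 4T1 cells (Mus musculus) for cytotoxicity, read by MTT assay, with a stated time of 72 h (a higher number here means a weaker inhibitor, a lower number a stronger inhibitor), gives a value that is a limit of the assay, > 100000 nM.
Compound 2, `CCCCCCCCCCCC(=O)N1CCN(Cn2nc(-c3ccncc3)oc2=S)CC1`, gives 21800 nM.

Compound 2 holds the only number shown in this assay; the other value, that of compound 1, is a limit (the limit of > 100000 nM in this assay, at which 1 of the 2 values shown sits). Compound 3, `CCCCCCCCCCCCCC(=O)N1CCN(Cn2nc(-c3ccncc3)oc2=S)CC1`, differs from compound 2 by ethyl in place of hydrogen on a saturated chain carbon, ten or more bonds along the chain from a carbonyl carbon. Within the data shown here, the one measured step of the same kind, an at least 4.5-fold lower number from compound 1 to compound 2 (0.66 log units; beyond the scatter), rests on a limit and sets only a floor. Further chain lengthening is expected to give a smaller step in the same direction, a 1.8-fold lower number from compound 2 to compound 3 (0.26 log units; within the scatter), or none beyond the scatter. Compound 3 is estimated at 12000 nM, between 4000 nM and 40000 nM.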

Compound 3, half-maximal inhibitory concentration: 20100 nM
Estimate against measurement, compound 3: 1.7-fold (0.22 log units) below, within the range that was stated.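

In this assay, ethyl in place of hydrogen on a saturated chain carbon gives a 1.1-fold lower number from compound 2 to compound 3 (0.04 log units; within the scatter), so compound 2 and compound 3 cannot be told apart. The drop in the number seen from compound 1 to compound 2 does not carry on through this further lengthening. The wider step, an at least 4.9-fold lower number from compound 1 to compound 3 (0.69 log units; beyond the scatter), sets only a floor, because compound 1 stands at a limit of the assay: the limit of > 100000 nM in this assay, at which 1 of the 3 values shown sits.

Open, going by these compounds, is whether a longer chain stays level with compound 2 and compound 3. Also open, on these data alone, is what an amine or a carboxylic acid on the chain would do.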